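A Dinitrophenyl Variant Where Both Neighbours Sit at Limits

A few compounds are considered here, and "the series" means these few. Any claim that something is new, unique, unknown or untested is made for them only; others in the source may bear on it.

Compound 2 `N#CC1=C(N)Oc2c(N)cc3nc4ccccc4nc3c2C12C(=O)N(Cc1cnnn1-c1ccc(F)c(Cl)c1)c1ccccc12` carries a 3-chloro-4-fluorophenyl group on an aromatic nitrogen of the shared core. In a functional assay on HCT-116 cells (Homo sapiens) for antiproliferative activity, read by MTT assay, with a stated time of 48 h (a higher number here means a weaker inhibitor, a lower number a stronger inhibitor), compound 2 gives only a limit of the assay, > 50000 nM. Its neighbour, compound 1 `N#CC1=C(N)Oc2c(N)cc3nc4ccccc4nc3c2C12C(=O)N(Cc1cnnn1-c1cc(Cl)ccc1Cl)c1ccccc12`, bears a 2,5-dichlorophenyl group at that nitrogen instead. In this assay compound 1 likewise gives only a limit, > 50000 nM. The step that the two limits leave unreadable from compound 1 to compound 2 cannot be read, and the pair shows nothing beyond the fact that both values sit at the limit of > 50000 nM in this assay, at which 2 of the 2 values shown sit.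

Compound 3 `N#CC1=C(N)Oc2c(N)cc3nc4ccccc4nc3c2C12C(=O)N(Cc1cnnn1-c1ccc([N+](=O)[O-])cc1[N+](=O)[O-])c1ccccc12` introduces the next change: 2,4-dinitrophenyl in place of 3-chloro-4-fluorophenyl on an aromatic nitrogen. For the measured compounds named here, no measured step gives a readable size that bears on this exchange; the single step between the two neighbours is hidden behind their limits. Compound 3 is therefore expected to stay at the limit as well, with an estimate of 50000 nM, between 10000 nM and 200000 nM. The expected step of a number no higher from compound 2 to compound 3 (the limit leaves the size open) is, on this reading, nothing beyond the scatter.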

Compound 3, half-maximal inhibitory concentration: 23900 nM
Compound 3: the middle estimate sits 2.1-fold (0.32 log units) above what was measured, and the stated range covers the measured number.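

With 2,4-dinitrophenyl on the aromatic nitrogen, the series yields its first number rather than a limit: in this assay, compound 3 gives 23900 nM. This shows that the group at this position can shift the antiproliferative read-out, with an at least 2.0-fold lower number from compound 2 to compound 3 (0.32 log units; beyond the scatter) and an at least 2.0-fold lower number from compound 1 to compound 3 (0.32 log units; beyond the scatter), whereas the exchange between the two halogenated phenyl groups could not be read. The true size of both steps stays unknown, as each has a limit at one end: the limit of > 50000 nM in this assay, at which 2 of the 3 values shown sit.

The compounds shown leave open whether a single nitro group on the phenyl ring would give a similar step, or whether both are needed. They also leave open how an amine or a carboxylic acid on that ring would compare with the two nitro groups.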